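A few compounds are considered here, and "the series" means these few. Any claim that something is new, unique, unknown or untested is made for them only; others in the source may bear on it.

Compound 1 `COc1ccc(-c2coc(=O)n2-c2cc(OC)c(OC)c(OC)c2)cc1` and compound 2 `COc1cc(-n2c(-c3ccc4ccccc4c3)coc2=O)cc(OC)c1OC` share the same core and were both tested in a functional assay on PC-3 cells (Homo sapiens) for inhibition; a lower number here means a stronger inhibitor, a higher number a weaker inhibitor. There compound 1 gives 7.5 nM, the higher of the two numbers, while compound 2 gives 3.1 nM, a difference that lies beyond the usual scatter. Compound 3 `COc1ccc(-c2coc(=O)n2-c2cc(OC)c(OC)c(OC)c2)cc1O` has not been measured yet; it differs from compound 1 by hydroxy in place of hydrogen on an aromatic carbon. Among the compounds with values here, no measured pair shows this change, so the direction is uncertain, but a small step, if any, is expected from compound 1 to compound 3, as a 1.5-fold lower number from compound 1 to compound 3 (0.18 log units; within the scatter). Compound 3 is therefore estimated at 5 nM, with a likely range from 1.5 nM to 20 nM.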

Compound 3, half-maximal inhibitory concentration: 2.3 nM
Estimate against measurement, compound 3: 2.2-fold (0.34 log units) above; measured number inside the range.
By their numbers in this assay, from the lowest: compounds 3 and 2 (each within the scatter of the next); then compound 1.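

Placing hydroxy on the aromatic carbon ortho to the methoxy group, which turns 4-methoxyphenyl into 3-hydroxy-4-methoxyphenyl, gives a 3.3-fold lower number from compound 1 to compound 3 (0.51 log units; beyond the scatter) in this assay. This position therefore accepts a hydroxy group, and this one change yields a gain in inhibition that exceeds the usual scatter. Nothing available explains this gain.

From the compounds shown here alone, whether an amine or a fluorine on the same carbon would do as well remains open. So does whether adding hydroxy to compound 2 would give a similar step.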